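A few compounds are considered here, and "the series" means these few. Any claim that something is new, unique, unknown or untested is made for them only; others in the source may bear on it.

Compound 1 `CNC(=O)c1cc(Oc2ccc3nc(Nc4cccc(C(C)(C)C)c4)ccc3c2)ccn1` and compound 2 `CNC(=O)c1cc(Oc2ccc3nc(Nc4cccc(C(F)(F)F)c4)ncc3c2)ccn1` are two close relatives measured for a physicochemical assay for solubility, at pH 7; a higher number here means a more soluble compound, a lower number a less soluble compound. For compound 1 the result is a limit of the assay, < 1000 nM. For compound 2 the result is likewise only a limit, < 1000 nM, so compound 2 stands at the floor of what this assay reports, where both shown values sit (the limit of < 1000 nM in this assay, at which 2 of the 2 values shown sit). Compound 3 `CNC(=O)c1cc(Oc2ccc3nc(Nc4ccc(OC(F)(F)F)cc4)ncc3c2)ccn1` carries 4-(trifluoromethoxy)phenyl in place of 3-(trifluoromethyl)phenyl on a nitrogen on an aromatic ring. Within the data shown here, with no measured step to lean on, the change from compound 2 to compound 3 is expected to stay within the scatter, a step that the limit leaves unreadable from compound 2 to compound 3. Compound 3 is therefore expected to give about 500 nM, somewhere between 80 nM and 3000 nM.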

Compound 3, solubility: < 1000 nM
Compound 3: no number, only a limit; the forecaster's own chance of this, stated with the estimate: 70%; the middle value lies beyond the limit too.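

Compound 3 gives < 1000 nM in this assay, which is a limit and not a number. As far as these compounds go, no step can be read from compound 2 to compound 3, because both stand at the same limit: the limit of < 1000 nM in this assay, at which 3 of the 3 values shown sit. How soluble these three compounds actually are, and how they rank against one another, stays open.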